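The source may report more compounds than this note shows. Statements on the series, on what has been measured and on what is new or still open speak of the compounds shown alone.

In an ADME assay on BaF3 cells (Mus musculus) for antiproliferative activity, read by CCK-8 assay, with a stated time of 72 h (a lower number here means a stronger inhibitor of growth, a higher number a weaker inhibitor of growth), compound 3 (`CN1CCN(Cc2ccc(NC(=O)CCSc3ccc4c(-c5cccnc5)n[nH]c4c3)cc2C(F)(F)F)CC1`) gives 2650 nM, close to compound 1 (`Cc1n[nH]c2cc(SCCC(=O)Nc3ccc(CN4CCN(C)CC4)c(C(F)(F)F)c3)ccc12`) at 3900 nM and weaker than compound 2 (`CN1CCN(Cc2ccc(NC(=O)CCSc3ccc4c(-c5ccccc5)n[nH]c4c3)cc2C(F)(F)F)CC1`) at 600 nM. Compound 4 (`CN1CCN(Cc2ccc(NC(=O)CCSc3ccc4c(-c5cnn(C)c5)n[nH]c4c3)cc2C(F)(F)F)CC1`) differs from compound 3 in one group: 1-methyl-1H-pyrazol-4-yl in place of pyridin-3-yl on an aromatic carbon. This puts 1-methyl-1H-pyrazol-4-yl in place of pyridin-3-yl on an aromatic carbon. Among the compounds with values here, three measured steps bear on this place: a 6.5-fold lower number from compound 1 to compound 2 (0.81 log units; beyond the scatter) for phenyl in place of methyl, a 1.5-fold lower number from compound 1 to compound 3 (0.17 log units; within the scatter) for pyridin-3-yl in place of methyl, and a 4.4-fold higher number from compound 2 to compound 3 (0.65 log units; beyond the scatter) for pyridin-3-yl in place of phenyl. None of them swaps one nitrogen-containing aromatic ring for another, so no step beyond the scatter is expected in this assay. The expected change is a 1.3-fold lower number from compound 3 to compound 4 (0.12 log units; within the scatter). Compound 4 is estimated at 2000 nM, within an expected range of 700 nM to 5500 nM.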

Compound 4, concentration for 50% growth inhibition: 1400 nM
Compound 4: middle estimate off by 1.4-fold (0.15 log units), on the high side; measured number inside the range.
By their numbers in this assay, from the lowest: compound 2; then compounds 4, 3 and 1 (each within the scatter of the next, the first and the last beyond it).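

In this assay the change from pyridin-3-yl to 1-methyl-1H-pyrazol-4-yl is a 1.9-fold lower number from compound 3 to compound 4 (0.28 log units; within the scatter) and so does not separate these two rings at this position. The five-membered ring does separate from the other two groups, with a 2.8-fold lower number from compound 1 to compound 4 (0.44 log units; beyond the scatter) for its swap with methyl and a 2.3-fold higher number from compound 2 to compound 4 (0.37 log units; beyond the scatter) for its swap with phenyl, so neither nitrogen-containing ring reaches the phenyl value. No measurement shown here explains these steps.

Going by these compounds, it remains open whether any nitrogen-containing ring can match phenyl here. On these data alone, the effect of an amine or a carboxylic acid on the ring at this position, or of a longer chain in its place, also remains open.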